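Acetyl in place of hydrogen on the aromatic ring

A few compounds are considered here, and "the series" means these few. Any claim that something is new, unique, unknown or untested is made for them only; others in the source may bear on it.

Compound 2 `O=C(CSC(=S)N[C@H]1CCOC1=O)Nc1ccccc1` carries the shared core with an unsubstituted aromatic ring. In a functional assay on EC9706 cells (Homo sapiens) for cytotoxicity, read by MTT assay, with a stated time of 72 h (a higher number here means a weaker inhibitor, a lower number a stronger inhibitor), compound 2 gives > 128000 nM, which is a limit of the assay and not a number. Among the compounds with values here, compound 1 `O=C(CSC(=S)N[C@H]1CCOC1=O)Nc1cccc(Cl)c1` is the one compound of the three with a number: in this assay compound 1 gives 107000 nM. Compound 3 `O=C(CSC(=S)N[C@H]1CCOC1=O)Nc1cccc([N+](=O)[O-])c1` in this assay gives > 128000 nM, again a limit and not a number. The limit is shared, (the limit of > 128000 nM in this assay, at which 2 of the 3 values shown sit). The measured steps are an at least 1.1-fold higher number from compound 1 to compound 2 (0.07 log units; that floor lies within the scatter) and an at least 1.1-fold higher number from compound 1 to compound 3 (0.07 log units; that floor lies within the scatter); the step that the two limits leave unreadable from compound 2 to compound 3 cannot be sized because both ends are limits.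

Compound 4 `CC(=O)c1ccc(NC(=O)CSC(=S)N[C@H]2CCOC2=O)cc1` differs from compound 2 by acetyl in place of hydrogen on an aromatic carbon. Within the data shown here, none of the measured steps touches the same position, and the two that can be read, from compound 1 to compound 2 and from compound 1 to compound 3, both sit inside the scatter. No step beyond the scatter is therefore expected in this assay in either direction, and the expected step that the limit leaves unreadable from compound 2 to compound 4 is small. Compound 4 is estimated at 150000 nM, within 60000 nM to 400000 nM, and is expected most likely to be reported only as a limit in this assay.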

Compound 4, half-maximal inhibitory concentration: > 128000 nM
Compound 4 gave a limit, no number; the forecaster's own chance of this, stated with the estimate: 65%; the middle value is on the limit's open side.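

Compound 2 and compound 4 both stand at a limit and not a number in this assay, so the step between them cannot be read: the limit of > 128000 nM in this assay, at which 3 of the 4 values shown sit.

The compounds shown leave open the size and the direction of any step in this assay for acetyl in place of hydrogen on an aromatic carbon.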